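A 4-bromophenyl in place of 2,5-dimethoxyphenyl

This account rests on a few compounds, and the source may have more. Where it says the series, first, only, none or still open, it means among the compounds named here.

Within the data shown here, in a functional assay on CNE-2 cells (Homo sapiens) for antiproliferative activity, read by sulforhodamine B assay, with a stated time of 48 h (on this read-out lower numbers stand for stronger inhibition and higher numbers for weaker inhibition), compound 1 `COc1ccc(-c2ccccc2C(=O)/C=C/c2ccc(F)cc2)cc1OC` gives 5400 nM and compound 2 `COc1ccc(OC)c(/C=C/C(=O)c2ccccc2-c2ccc(OC)c(OC)c2)c1` gives 2400 nM, the lower of the two numbers measured so far. Among the measured compounds shown here, the only measured step, a 2.3-fold lower number from compound 1 to compound 2 (0.35 log units; beyond the scatter), is modest but beyond the scatter, and it brought in 2,5-dimethoxyphenyl in place of 4-fluorophenyl.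

Compound 3 `COc1ccc(-c2ccccc2C(=O)/C=C/c2ccc(Br)cc2)cc1OC` has not yet been measured. Its difference from compound 2 is this: 4-bromophenyl in place of 2,5-dimethoxyphenyl on a double-bonded chain carbon bound to a double-bonded chain carbon. In words, 4-bromophenyl stands in place of 2,5-dimethoxyphenyl on a double-bonded chain carbon bound to a double-bonded chain carbon. The change therefore removes the group that the measured step introduced. It leaves compound 3 closest at this place to compound 1, which carries 4-fluorophenyl and gives 5400 nM. For the measured compounds named here, no measured pair compares 4-bromophenyl with 4-fluorophenyl directly, so that single step is the only guide, and a loose one.

In this assay, the expected step is a 2.1-fold higher number from compound 2 to compound 3 (0.32 log units; beyond the scatter), towards a higher number and similar in size to the measured one. For compound 3 the estimate is 5000 nM, with an expected range from 2000 nM to 12000 nM.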

Compound 3, half-maximal inhibitory concentration: 4800 nM
Beside the measured number, compound 3's estimate is 1.0-fold (0.02 log units) above it, within the range that was stated.
By their numbers in this assay, from the lowest: compounds 2, 3 and 1 (each within the scatter of the next, the first and the last beyond it).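

In this assay, the step to 4-bromophenyl (a 2.0-fold higher number from compound 2 to compound 3 (0.30 log units; within the scatter)) lies within the scatter, so at this place on a double-bonded chain carbon bound to a double-bonded chain carbon, the numbers do not separate 4-bromophenyl from 2,5-dimethoxyphenyl. Among these compounds, the result also gives the first direct comparison of two halogens here: bromo in place of fluoro on an aromatic carbon (a 1.1-fold lower number from compound 1 to compound 3 (0.05 log units; within the scatter)) likewise stays within the scatter, and the two compounds cannot be ordered. Among the compounds shown here, compound 3 therefore sits within the scatter of both neighbours, and the only step of the three that can be read as a real difference remains the one that exchanged 4-fluorophenyl for 2,5-dimethoxyphenyl (a 2.3-fold lower number from compound 1 to compound 2 (0.35 log units; beyond the scatter)).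

The compounds shown leave open what a phenyl carrying an amine or a carboxylic acid would give at this place, since both groups that entered here and the one they replaced are of only two kinds, halogens and methoxy groups. They also leave open whether either methoxy group of 2,5-dimethoxyphenyl alone would match the pair, and nothing available bears on why the numbers fall as they do.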